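A few compounds are considered here, and "the series" means these few. Any claim that something is new, unique, unknown or untested is made for them only; others in the source may bear on it.

Working notes on the series. In an assay on L cells for inhibition of Protein-serine O-palmitoleoyltransferase porcupine (Mus musculus), read by reporter gene assay, with a stated time of 24 h (a higher number here means that more compound is needed for the effect, a lower number that less compound is needed), compound 1 `Cc1ccc2nc(NC(=O)CNC(=O)c3nn(-c4ccccc4)c(=O)c4ccccc34)sc2c1` gives 35 nM, compound 2 `COc1ccc(-n2nc(C(=O)NCC(=O)Nc3nc4ccc(C)cc4s3)c3ccccc3c2=O)cc1` gives 25 nM, and compound 3 `COc1ccccc1-n1c(SCC(=O)Nc2nc3ccc(Cl)cc3s2)nc2c(c1=O)SCC2` gives 50 nM. Compound 2 holds the lowest of the three numbers, yet its gaps to compound 1 and to compound 3 both lie within the scatter, so no order among the three can be read from these values. Within the data shown here, the only single-point step measured so far, a 1.4-fold lower number from compound 1 to compound 2 (0.15 log units; within the scatter), puts methoxy where there was hydrogen on an aromatic carbon and moves nothing beyond the scatter.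

Compound 4 `COc1ccc(-n2nc(C(=O)NCC(=O)Nc3nc4ccc(OC)cc4s3)c3ccccc3c2=O)cc1` has not yet been measured in this assay. Against compound 2 it carries methoxy in place of methyl on an aromatic carbon. Among the measured compounds shown here, no measured step exchanges methyl for methoxy at this place. Compound 3 carries chloro on the corresponding ring but sits on a different core, so only its own value can be consulted, and that value lies within the scatter of compound 2. Because a 1.4-fold lower number from compound 1 to compound 2 (0.15 log units; within the scatter) stayed within the scatter, the expectation for compound 4 is a step of a 1.2-fold higher number from compound 2 to compound 4 (0.08 log units; within the scatter), that is none beyond the scatter. Compound 4 is therefore estimated at 30 nM in this assay, with a range from 12 nM to 75 nM.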

Compound 4, half-maximal effective concentration: 60 nM
The estimate for compound 4 lay 2.0-fold (0.30 log units) below the measured number; the range from low to high includes it.
By their numbers in this assay, from the lowest: compounds 2, 1, 3 and 4 (each within the scatter of the next, the first and the last beyond it).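

On the shared core, the exchange read as 6-methyl-1,3-benzothiazol-2-yl to 6-methoxy-1,3-benzothiazol-2-yl gives a 2.4-fold higher number from compound 2 to compound 4 (0.38 log units; beyond the scatter) in this assay, a modest step but the only single-place change shown here that goes beyond the scatter. Methoxy entering elsewhere, in place of hydrogen, gave a 1.4-fold lower number from compound 1 to compound 2 (0.15 log units; within the scatter) and stayed within the scatter, so the series now shows that this aromatic carbon of the fused system responds to a change that the earlier step elsewhere on the molecule did not reveal, with methyl giving the lower number of the two groups compared here. Nothing available on these compounds accounts for the direction or size of this step.

Going by these compounds, only methyl and methoxy can be compared directly at this carbon on this core, so what a fluoro group, a hydroxy group, an ethoxy group or an amine would give there remains open. Also open, on these data alone, is whether the same exchange gives a step of similar size on compound 1, which lacks the methoxy that compound 2 and compound 4 share on their other ring.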